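Ester chain variation in the cinnamate series: compound 3

The source may hold more compounds than are shown below. What is called first, only, known or untested is meant among the compounds shown, and "the series" means these compounds.

Two esters of the shared core of compound 1 `CCCOC(=O)/C=C/c1ccc(NC(=O)C2(NC(=O)c3ccc4c(C5CCCC5)c(-c5ncc(Cl)cn5)n(C)c4c3)CCC2)cc1OCC` have been run in an ADME assay on stomach for pharmacokinetics, in simulated gastric fluid; a higher number here means that the compound lasts longer, a lower number that the compound disappears faster. Compound 1 gives 2.23 h. Compound 2 `CCCCCCOC(=O)/C=C/c1ccc(NC(=O)C2(NC(=O)c3ccc4c(C5CCCC5)c(-c5ncc(Cl)cn5)n(C)c4c3)CCC2)cc1OCC`, its hexyl ester, gives 0.883 h, the lowest of the two numbers; its nearest neighbour is compound 1. Going by the values given here, the single step available, a 2.5-fold lower number from compound 1 to compound 2 (0.40 log units; beyond the scatter), is a modest drop and the only one that touches the ester chain.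

Compound 3 `CCOc1cc(NC(=O)C2(NC(=O)c3ccc4c(C5CCCC5)c(-c5ncc(Cl)cn5)n(C)c4c3)CCC2)ccc1/C=C/C(=O)OCC(=O)N1CCOCC1`, not yet measured, differs from compound 2 by (morpholin-4-yl)carbonyl in place of pentyl on a saturated chain carbon bound to an oxygen next to a carbonyl group. The step from compound 1 to compound 2 bears on it only loosely: both changes sit in the ester chain, but the group entering here is not a chain extension, so its direction cannot be read from that step. A modest move in either direction is therefore expected in this assay, and the estimate leans toward the value of compound 1 rather than away from it.

For compound 3 the expected half-life in this assay is 1.5 h, within a range of 0.6 h to 4 h, which corresponds to an expected step of a 1.7-fold higher number from compound 2 to compound 3 (0.23 log units; within the scatter).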

Compound 3, half-life: 0.85 h
Beside the measured number, compound 3's estimate is 1.8-fold (0.25 log units) above it; low and high end bracket the measured number.
By their numbers in this assay, from the lowest: compounds 3 and 2 (each within the scatter of the next); then compound 1.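

In this assay, (morpholin-4-yl)carbonyl in place of pentyl on the saturated chain carbon bound to an oxygen next to a carbonyl group gives a 1.0-fold lower number from compound 2 to compound 3 (0.02 log units; within the scatter) and so leaves the two esters indistinguishable, although the entering group brings a six-membered non-aromatic ring and hydrogen-bond acceptors that pentyl lacks. The same group in place of ethyl gives a 2.6-fold lower number from compound 1 to compound 3 (0.42 log units; beyond the scatter) and places compound 3 with compound 2, clear of compound 1. A lower number at this position therefore accompanies both a straight hexyl chain and a ((morpholin-4-yl)carbonyl)methyl group, so chain extension is not the only change linked to it among these three esters, and no measurement here explains the shared result.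

Three esters cannot show whether compound 1 sits near an upper level for this position or whether a methyl ester, a branched isopropyl ester or a tert-butyl ester would raise the number further. As far as these compounds go, it also remains open how a chain ending in a dimethylamino group or a carboxylic acid would compare with the morpholine amide of compound 3 on the same core.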